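The source may hold more compounds than are shown below. What is called first, only, known or untested is meant among the compounds shown, and "the series" means these compounds.

Values in a functional assay on SK-MEL-147 cells (Homo sapiens) for cytotoxicity, read by MTT assay, with a stated time of 24 h (a higher number here means that more compound is needed for the effect, a lower number that less compound is needed), for the measured compounds:

Compound 1 `COc1ccc2nc(-c3c(Cl)cccc3Cl)cc([Se]c3ccccc3)c2c1`: > 150000 nM
Compound 2 `COc1ccc([Se]c2cc(-c3ccc(O)cc3)nc3ccc(OC)cc23)cc1`: 59200 nM
Compound 3 `CCOC(=O)c1cc([Se]c2ccc(OC)cc2)c2cc(OC)ccc2n1`: >= 54300 nM

Compound 1 stands at a limit of this assay, not at a number, as noted in the limit of > 150000 nM in this assay, at which 1 of the 3 values shown sits. Compound 3 likewise sits at a limit, see (the limit of >= 54300 nM in this assay, at which 1 of the 3 values shown sits). Only compound 2 returns a number, and it is a weak one. Among the measured compounds shown here, the single measured step, a step that the limit leaves unreadable from compound 2 to compound 3, is therefore unreadable, since the limit on compound 3 hides its size.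

Compound 4 `COc1ccc2nc(-c3cccs3)cc([Se]c3ccccc3)c2c1` is the next compound to be measured. It differs from compound 1 by thiophen-2-yl in place of 2,6-dichlorophenyl on an aromatic carbon. For the measured compounds named here, no measured step speaks to this change: the one step on record is unreadable, and no other pair differs at this place. Going by the values given here, nothing so far shows any compound reaching a readable, strong value, so compound 4 is expected to remain weak as well. The step of a number no higher from compound 1 to compound 4 (the limit leaves the size open) is expected to be small or unreadable, since compound 1 itself is a limit. Compound 4 is estimated at 150000 nM, within 40000 nM to 500000 nM, with a fair chance that the assay again reports only a limit.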

Compound 4, half-maximal effective concentration: > 150000 nM
Compound 4: no number, only a limit; the forecaster's own chance of this, stated with the estimate: 65%; the middle value sits exactly at the limit.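

In this assay, among the compounds shown here, compound 4 gives > 150000 nM, a limit and not a number, and compound 1 sits at the same limit, so no step between these two compounds can be read. From the compounds shown here alone, whether thiophen-2-yl and 2,6-dichlorophenyl differ in this read-out remains open.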